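A few compounds are considered here, and "the series" means these few. Any claim that something is new, unique, unknown or untested is made for them only; others in the source may bear on it.

In a physicochemical assay for solubility (a higher number here means a more soluble compound, a lower number a less soluble compound), compound 1 `O=C(c1ccccc1)N1CCC(NS(=O)(=O)c2cc(S(=O)(=O)c3ccccc3)ccc2C(F)(F)F)CC1` gives 12500 nM. Compound 3 `O=C(O)c1ccc(S(=O)(=O)N2CCC(NS(=O)(=O)c3cc(S(=O)(=O)c4ccccc4)ccc3C(F)(F)F)CC2)cc1` gives 12500 nM, so that compound 1 stands level with compound 3 and the two share the highest number of the three. Compound 2 `O=C(c1cccc(Cl)c1)N1CCC(NS(=O)(=O)c2cc(S(=O)(=O)c3ccccc3)ccc2C(F)(F)F)CC1` gives 6300 nM; the remaining step is a 2.0-fold lower number from compound 1 to compound 2 (0.30 log units; within the scatter). Compound 4 `CC(C)(O)CCN1CCC(NS(=O)(=O)c2cc(S(=O)(=O)c3ccccc3)ccc2C(F)(F)F)CC1` differs from compound 1 by 3-hydroxy-3-methylbutyl in place of benzoyl on an amine nitrogen in a ring. The measured steps that bear on this change are those at the same amine nitrogen in a ring: no change at the digits printed from compound 1 to compound 3 (within the scatter) and a 2.0-fold higher number from compound 2 to compound 3 (0.30 log units; within the scatter), both within the scatter. Since exchanges at that position have so far moved nothing beyond the scatter, no step beyond the scatter is expected in this assay. For compound 4 the expected value is 15000 nM, within a range of 6000 nM to 40000 nM, which amounts to an expected step of a 1.2-fold higher number from compound 1 to compound 4 (0.08 log units; within the scatter).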

Compound 4, solubility: 50000 nM
Compound 4: middle estimate off by 3.3-fold (0.52 log units), on the low side; measured number outside the range, above it.
By their numbers in this assay, from the lowest: compounds 2, 1 and 3 (each within the scatter of the next); then compound 4.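

In this assay the amine nitrogen in a ring now proves able to move the number beyond the scatter: 3-hydroxy-3-methylbutyl gives a 4.0-fold higher number from compound 1 to compound 4 (0.60 log units; beyond the scatter) and a 4.0-fold higher number from compound 3 to compound 4 (0.60 log units; beyond the scatter) and also a 7.9-fold higher number from compound 2 to compound 4 (0.90 log units; beyond the scatter) in the same direction. Among the compounds shown, the three groups with an aromatic ring on that nitrogen lie within the scatter of their neighbours, and the one group with no ring stands apart from all of them. Nothing measured here accounts for this difference.

On these data alone, whether the hydroxy group or the absence of a ring goes with the step stays open. A plain alkyl chain or an amine on that nitrogen would help to separate the two.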